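The compounds below may be only part of what the source reports. "The series", "measured", "known", "first", "only" and "open" are said of these compounds alone.

Compound 2 `CN(C)CCN1CCN(c2nc(-c3ccccn3)nc3c2CN(Cc2ccccc2)CC3)CC1` carries a 4-(2-(dimethylamino)ethyl)piperazin-1-yl group on an aromatic carbon of the shared core. In an assay on A549 cells with Cystic fibrosis transmembrane conductance regulator variant F508del (Homo sapiens) as the target, read by fluorescence, with a stated time of 25 min (a lower number here means a smaller maximal response, a higher number a larger maximal response), compound 2 gives 57%, the highest of the two numbers measured here. For the measured compounds named here, compound 1 `OC1CCCN(c2nc(-c3ccccn3)nc3c2CN(Cc2ccccc2)CC3)C1`, which bears 3-hydroxypiperidin-1-yl at that place, gives 30.6% in this assay, and the step of a number 26.4 percentage points higher from compound 1 to compound 2 (beyond the scatter) is the only measured step in the set. Compound 3 `CN(C)CCN1CCN(c2nc(-c3cccnc3)nc3c2CN(Cc2ccccc2)CC3)CC1` is reported in this assay as "not active" (no number reported), without a number.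

Compound 4 `CN(C)CCN1CCN(c2nc(-c3ccccn3)nc3c2CN(S(=O)(=O)c2ccccc2)CC3)CC1` has not yet been measured. It differs from compound 2 at a different place: phenylsulfonyl in place of benzyl on an amine nitrogen in a ring. No measured pair changes the group on that amine nitrogen in a ring, so no step shown here bears directly on this change; the one known step, from compound 1 to compound 2, concerns the aromatic carbon instead. The direction of any change in this assay is therefore open, and a number 12 percentage points lower from compound 2 to compound 4 (beyond the scatter) is expected to stay small relative to the uncertainty. For compound 4 the estimate in this assay is 45%, with a range from 15% to 70%.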

Compound 4, largest response reached (Emax), in percent of the reference or control that the assay uses: "not active" (no number reported)
Nothing numeric was reported for compound 4; there is nothing to compare the estimate with.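

For the compounds shown here, compound 4 gives no number in this assay, so no step from compound 2 to compound 4 can be read. Nothing shown explains this result. From the compounds shown here alone, how far phenylsulfonyl in place of benzyl lowers the response, if it does, remains open.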